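Nitro Group in Place of Two Fluorines on the Amide Ring

The compounds below may be only part of what the source reports. "The series", "measured", "known", "first", "only" and "open" are said of these compounds alone.

Compound 1 `O=C(Nc1cccc(-c2oc3cc(-c4ccc(F)cc4)ccc3c(=O)c2O)c1)c1ccc(Cl)cc1` gives 4730 nM in a functional assay on MCF7 cells (Homo sapiens) for antiproliferative activity, read by CCK-8 assay, with a stated time of 72 h; a higher number here means a weaker inhibitor, a lower number a stronger inhibitor.
Compound 2 `O=C(Nc1cccc(-c2oc3cc(-c4ccc(F)cc4)ccc3c(=O)c2O)c1)c1ccc(Br)cc1` gives 24000 nM in this assay.
Compound 3 `O=C(Nc1cccc(-c2oc3cc(-c4ccc(F)cc4)ccc3c(=O)c2O)c1)c1cc(F)cc(F)c1` gives 2490 nM in this assay.

All three share one core and differ only in the ring attached to the amide carbonyl. Compound 3 and compound 1 sit within the scatter of each other, as a 1.9-fold lower number from compound 1 to compound 3 (0.28 log units; within the scatter) shows, so neither can be called the stronger inhibitor. Compound 2 stands clearly apart: a 5.1-fold higher number from compound 1 to compound 2 (0.71 log units; beyond the scatter) and a 9.6-fold lower number from compound 2 to compound 3 (0.98 log units; beyond the scatter) both lie beyond the scatter.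

Compound 4 `O=C(Nc1cccc(-c2oc3cc(-c4ccc(F)cc4)ccc3c(=O)c2O)c1)c1ccc([N+](=O)[O-])cc1` has not yet been measured in this assay. The change is 4-nitrophenyl in place of 3,5-difluorophenyl on a carbonyl carbon. Going by the values given here, no measured step swaps in a nitro group, so the nearest guidance comes from the other ring changes at the same carbonyl carbon: one small and within the scatter, one modest and beyond it. The expected step is therefore a 2.0-fold higher number from compound 3 to compound 4 (0.30 log units; within the scatter), with wide uncertainty. Compound 4 is estimated at 5000 nM in this assay, with a range from 1500 nM to 20000 nM.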

Compound 4, half-maximal inhibitory concentration: 3970 nM
Compound 4: the middle estimate sits 1.3-fold (0.10 log units) above what was measured; measured number inside the range.
By their numbers in this assay, from the lowest: compounds 3, 4 and 1 (each within the scatter of the next); then compound 2.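

Placing 4-nitrophenyl on the carbonyl carbon, a ring with hydrogen-bond acceptors where 3,5-difluorophenyl has none, gives a 1.6-fold higher number from compound 3 to compound 4 (0.20 log units; within the scatter), and nitro in place of chloro gives a 1.2-fold lower number from compound 1 to compound 4 (0.08 log units; within the scatter), so in this assay neither change separates these compounds. Nitro in place of bromo instead gives a 6.0-fold lower number from compound 2 to compound 4 (0.78 log units; beyond the scatter), which leaves compound 2 as the one compound of the four that stands apart and shows that three quite different rings can share a single band of values at this position, with compound 2 as the exception. Nothing available here explains why bromo parts from chloro and nitro at the same place on the ring.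

The compounds shown leave open whether an amine or a carboxylic acid on this ring would stay with compound 1, compound 3 and compound 4 or fall away like compound 2. They also leave open whether a methoxy group or an iodo group in the same place would follow the nitro and chloro compounds or the bromo compound.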